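This account rests on a few compounds, and the source may have more. Where it says the series, first, only, none or still open, it means among the compounds named here.

Compound 1 `COc1cc(-c2nnc3n2NC(c2ccco2)C(C(=O)c2ccccc2C)S3)cc(OC)c1OC` carries a 2-methylphenyl group on the carbonyl carbon of the shared core, and in a functional assay on MCF7 cells (Homo sapiens) for cytotoxicity, read by MTT assay, with a stated time of 48 h (on this read-out higher numbers stand for weaker inhibition and lower numbers for stronger inhibition), compound 1 gives 69900 nM. Compound 2 `COc1cc(-c2nnc3n2NC(c2ccco2)C(C(=O)c2ccccc2F)S3)cc(OC)c1OC` gives 94800 nM. Compound 3 `COc1cc(-c2nnc3n2NC(c2ccco2)C(C(=O)c2ccc(C)cc2)S3)cc(OC)c1OC` gives only a limit of the assay, > 100000 nM. Of the two numbers recorded, compound 2 holds the higher one, yet its distance from compound 1 is small: a 1.4-fold higher number from compound 1 to compound 2 (0.13 log units; within the scatter). The change from compound 1 to compound 3 reads an at least 1.4-fold higher number from compound 1 to compound 3 (0.15 log units; that floor lies within the scatter), and from compound 2 to compound 3 an at least 1.0-fold higher number from compound 2 to compound 3 (0.02 log units; that floor lies within the scatter). Every recorded step therefore stays within the scatter, and one of them ends at the limit of > 100000 nM in this assay, at which 1 of the 3 values shown sits.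

Compound 4 `COc1cc(-c2nnc3n2NC(c2ccco2)C(C(=O)c2cccc(Br)c2)S3)cc(OC)c1OC` is not yet measured. It differs from compound 2 in this way: 3-bromophenyl in place of 2-fluorophenyl on a carbonyl carbon. Going by the values given here, the steps that bear on it are those that swap the aryl group on the same carbonyl carbon, and none of them moved the read-out beyond the scatter. In this assay the expectation for compound 4 is therefore no change beyond the scatter, so a step of a 1.1-fold higher number from compound 2 to compound 4 (0.02 log units; within the scatter) is estimated from compound 2. Compound 4 is expected to give about 100000 nM, within a range of 50000 nM to 200000 nM, with a fair chance that only a limit is reported.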

Compound 4, half-maximal inhibitory concentration: 91800 nM
The estimate for compound 4 lay 1.1-fold (0.04 log units) above the measured number, and the stated range covers the measured number.
By their numbers in this assay, from the lowest: compounds 1, 4 and 2 (each within the scatter of the next). At a limit, above all of these: compound 3.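

Going by these compounds alone, with 3-bromophenyl, the aryl group on this carbonyl carbon now carries a bromine, a heavier halogen than the fluorine of compound 2, and its substituent sits at a ring position not seen in the earlier compounds, yet in this assay the read-out stays put: a 1.0-fold lower number from compound 2 to compound 4 (0.01 log units; within the scatter), and a 1.3-fold higher number from compound 1 to compound 4 (0.12 log units; within the scatter). Compound 3 gives only a limit of the assay, so its comparison with the new compound is a floor and not a true size, and that floor also stays small: an at least 1.0-fold lower number from compound 3 to compound 4 (0.03 log units; that floor lies within the scatter). Across these four aryl groups no step leaves the scatter, so swapping methyl, fluorine or bromine around this phenyl ring has not separated the compounds, and compound 3 remains the only one at a limit: the limit of > 100000 nM in this assay, at which 1 of the 4 values shown sits.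

As far as these compounds go, what an amine or a carboxylic acid on this phenyl ring, or a longer alkyl chain in place of the ring, would do to the read-out stays open. The rest of the shared core is the same in all four compounds, so these numbers say nothing about changes made elsewhere on it.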